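The source may hold more compounds than are shown below. What is called first, only, known or untested is meant among the compounds shown, and "the series" means these compounds.

Measured so far:
Compound 1 `CC(C)c1onc(-c2c(Cl)cccc2Cl)c1COc1ccc(N(C)C(=O)c2ccc(C(=O)O)cc2)c(C(F)(F)F)n1` — 208 nM
Compound 2 `Cc1cc(OCc2c(-c3c(Cl)cccc3Cl)noc2C(C)C)ncc1[N+](=O)[O-]` — 1140 nM

Both compounds were tested in a functional assay on HEK293 cells for agonist activity at Bile acid receptor (Homo sapiens), read by a luciferase reporter; on this read-out higher numbers stand for an effect only at larger amounts of compound and lower numbers for an effect already at smaller amounts. Compound 1 has the lower of the two numbers; compound 2 lies beyond the usual scatter from it, so the gap between them is real. The two structures differ in more than one place, so nothing more than that can be read from the pair.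

Compound 3 `CC(C)c1onc(-c2c(Cl)cccc2Cl)c1COc1ccc(N(C)Cc2cccc(C(=O)O)c2)c(C(F)(F)F)n1` has not been measured. It keeps the core of compound 1 and differs in one place: 3-carboxybenzyl in place of (4-carboxyphenyl)carbonyl on a nitrogen on an aromatic ring. Among the measured compounds shown here, no measured pair in this set shows what such a change does, so the expectation rests on the change itself. With the carbonyl gone and the carboxylic acid moved to a different point on the ring, compound 3 is expected to show a higher number than compound 1, the step of a 3.8-fold higher number from compound 1 to compound 3 (0.59 log units; beyond the scatter) being beyond the scatter. Compound 3 is thus estimated at 800 nM, within a range from 200 nM to 4000 nM.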

Compound 3, half-maximal effective concentration: 6 nM
Compound 3: middle estimate off by 130-fold (2.12 log units), on the high side; the whole stated range lies above it.
By their numbers in this assay, from the lowest: compound 3; then compound 1; then compound 2.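

In this assay, the group on this nitrogen on an aromatic ring turns out to have a strong influence on the read-out: 3-carboxybenzyl in place of (4-carboxyphenyl)carbonyl gives a 35-fold lower number from compound 1 to compound 3 (1.54 log units; beyond the scatter). The result also shows that, on this core, the carbonyl linking the ring to the nitrogen is not required for a low number, while both groups carry a carboxylic acid. Nothing available here accounts for the size of this step.

This single change removes the carbonyl and also moves the carboxylic acid to a different point on the ring, so the compounds shown leave open which of the two carries the step. Also open, going by these compounds, is whether the carboxylic acid itself is needed, or whether an amine or a nitrile on that ring would give a similar number.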